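A few compounds are considered here, and "the series" means these few. Any claim that something is new, unique, unknown or untested is made for them only; others in the source may bear on it.

In a functional assay on the whole organism (strain Kunming) with Mus musculus as the target, with a stated time of 0.5 h (a higher number here means that more compound is needed for the effect, a lower number that less compound is needed), three compounds sharing one core have been tested. Compound 1 (`COc1cc(OC)c(OC)cc1/C=C/COC(=O)/C=C/c1ccc(OC)c(OC)c1`) gives only a limit, > 723 umol/kg. Compound 2 (`COc1cc(OC)c(OC)cc1/C=C/COC(=O)/C=C/c1cc(OC)c(OC)c(OC)c1`) also gives only a limit, > 450 umol/kg. Among the compounds with values here, compound 3 (`COc1cc(OC)c(OC)cc1/C=C/COC(=O)/C=C/c1cccc(Br)c1`), at 497 umol/kg, is the only one with an actual number. Compound 4 (`COc1cccc(/C=C/C(=O)OC/C=C/c2cc(OC)c(OC)cc2OC)c1`) puts methoxy in place of bromo on an aromatic carbon. Within the data shown here, two measured steps bear on this. One is a step that the two limits leave unreadable from compound 1 to compound 2, which tells nothing about size. The other is an at least 1.4-fold lower number from compound 1 to compound 3 (0.16 log units; that floor lies within the scatter), the swap that brought in the bromo. Neither supports a clear shift, so a change within the scatter is expected, leaning toward a higher number. The expected change is a 1.2-fold higher number from compound 3 to compound 4 (0.08 log units; within the scatter). For compound 4 the estimate is 600 umol/kg, with an expected range of 300 umol/kg to 1300 umol/kg.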

Compound 4, dose for half-maximal effect: 647 umol/kg
Compound 4: middle estimate off by 1.1-fold (0.03 log units), on the low side; the range from low to high includes it.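

In this assay, methoxy in place of bromo gives a 1.3-fold higher number from compound 3 to compound 4 (0.11 log units; within the scatter), so on this aromatic carbon the two groups cannot be told apart. Hydrogen in place of methoxy gives an at least 1.1-fold lower number from compound 1 to compound 4 (0.04 log units; that floor lies within the scatter), which is only a floor and also stays within the scatter. Compound 1 gives a limit, not a number: the limit of > 723 umol/kg in this assay, at which 1 of the 4 values shown sits.

Going by these compounds, what an amine or a carboxylic acid on this carbon would do stays open. So does whether any change at this position can move the number beyond the scatter.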